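Methyl on the Benzoyl Ring: Expected Cytotoxicity of Compound 3

A few compounds are considered here, and "the series" means these few. Any claim that something is new, unique, unknown or untested is made for them only; others in the source may bear on it.

Measured compounds:
compound 1, `COc1ccc([S+]([O-])c2cn(-c3ccc4c(c3)B(O)OC4)c3ccccc23)cc1`: > 10 ug/mL
compound 2, `O=C(c1ccccc1)c1ccn(-c2ccc3c(c2)B(O)OC3)c1`: > 10 ug/mL

Both measured compounds were tested in an ADME assay on L929 cells (Mus musculus) for cytotoxicity, read by resazurin assay, with a stated time of 72 h; a higher number here means a weaker inhibitor, a lower number a stronger inhibitor. In this assay compound 1 gives > 10 ug/mL, which is a limit of the assay rather than a number. In this assay compound 2 gives > 10 ug/mL, again a limit and not a number. Compound 2 thus sits at the same point as every value shown, summed up by the limit of > 10 ug/mL in this assay, at which 2 of the 2 values shown sit. The unmeasured compound 3, `Cc1ccccc1C(=O)c1ccn(-c2ccc3c(c2)B(O)OC3)c1`, differs from compound 2 by methyl in place of hydrogen on an aromatic carbon. Among the measured compounds shown here, no measured step is available to set the size of such a change. The step that the limit leaves unreadable from compound 2 to compound 3 is expected to be none beyond the usual scatter of this assay. Compound 3 is therefore estimated to give 15 ug/mL in this assay, within 8 ug/mL to 40 ug/mL, and most likely to be reported only as a limit once more.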

Compound 3, half-maximal inhibitory concentration: > 10 ug/mL
Compound 3 was reported as a limit; the forecaster's own chance of this, stated with the estimate: 80%; the middle value does not contradict the limit.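

Among the compounds shown here, compound 3, like compound 2, is reported only as a limit in this assay, so no step between compound 2 and compound 3 can be read. The compounds shown leave open the concentration at which any of them would reach half-maximal inhibition, as they share one result: the limit of > 10 ug/mL in this assay, at which 3 of the 3 values shown sit.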